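The source may report more compounds than this note shows. Statements on the series, on what has been measured and on what is new or still open speak of the compounds shown alone.

Among the compounds with values here, compound 2 `O=C(OCCc1c(-c2ccccc2Cl)c2cc(Cl)ccc2[nH]c1=O)C1CCCCC1` gives 38000 nM in an ADME assay on HepG2 2.2.15 cells (Homo sapiens) for cytotoxicity (on this read-out lower numbers stand for higher toxicity in this test and higher numbers for lower toxicity in this test), the lowest of the two numbers so far. Compound 1 `O=CCc1c(-c2ccccc2Cl)c2cc(Cl)ccc2[nH]c1=O` gives 120000 nM in this assay. Within the data shown here, the only measured step, a 3.2-fold lower number from compound 1 to compound 2 (0.50 log units; beyond the scatter), concerns a different change at another position, so no measured step covers an exchange of the acyl group. Compound 3 `COc1ccc(/C=C/C(=O)OCCc2c(-c3ccccc3Cl)c3cc(Cl)ccc3[nH]c2=O)cc1` differs from compound 2 by 2-(4-methoxyphenyl)ethenyl in place of cyclohexyl on a carbonyl carbon. With nothing comparable measured, a step no larger than the scatter is expected, a 1.3-fold lower number from compound 2 to compound 3 (0.10 log units; within the scatter). Compound 3 is therefore estimated at 30000 nM, with a range of 10000 nM to 90000 nM.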

Compound 3, half-maximal cytotoxic concentration: > 1200000 nM
Compound 3 gave a limit, no number; the forecaster's own chance of this, stated with the estimate: 10%; middle value at least 40-fold (1.60 log units) away from the limit.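

The acyl group on the ester carbonyl proves to be a sensitive place in this assay: 2-(4-methoxyphenyl)ethenyl in place of cyclohexyl gives an at least 31-fold higher number from compound 2 to compound 3 (1.49 log units; beyond the scatter), which points to lower toxicity in this test. Compound 3 reads > 1200000 nM, a limit and not a number, so the step has no upper end: the limit of > 1200000 nM in this assay, at which 1 of the 3 values shown sits.

Open, on these data alone, is which part of the entering group goes with this step: the ring, the methoxy or the double bond. A plain phenyl or a saturated 2-phenylethyl group on the same carbonyl carbon would separate them.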